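Moving the methyl on the sulfonyl aryl ring

A few compounds are considered here, and "the series" means these few. Any claim that something is new, unique, unknown or untested is made for them only; others in the source may bear on it.

Compound 1 `CCN(CC)Cc1ccc(S(=O)(=O)NCc2ccc(CNC(=O)c3ccc(F)cc3)cc2)cc1` gives 1 nM in an assay on MDA-MB-231 cells for binding affinity to C-X-C chemokine receptor type 4 (Homo sapiens), read by fluorescence and microscopy, with stated times of 10 min and 30 min; a higher number here means that more compound is needed for the effect, a lower number that less compound is needed. Compound 2 `Cc1ccccc1S(=O)(=O)NCc1ccc(CNC(=O)c2ccc(F)cc2)cc1` stands at the higher of the two numbers, giving 100 nM in this assay, a gap beyond the usual scatter. Compound 3 `Cc1cccc(S(=O)(=O)NCc2ccc(CNC(=O)c3ccc(F)cc3)cc2)c1` is not yet measured; it carries 3-methylphenyl in place of 2-methylphenyl on a sulfonyl sulfur. The two groups are the same size, so nothing like the gap between compound 1 and compound 2 is anticipated. A small step, a 1.7-fold lower number from compound 2 to compound 3 (0.22 log units; within the scatter), is expected, toward a somewhat lower number but possibly within the scatter. Compound 3 is estimated at 60 nM in this assay, with a range from 15 nM to 250 nM.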

Compound 3, effective concentration (reported as EC, without a stated level of effect): 1 nM
Beside the measured number, compound 3's estimate is 60-fold (1.78 log units) above it, and the stated range ends above it.
By their numbers in this assay, from the lowest: compounds 1 and 3 (each within the scatter of the next); then compound 2.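

In this assay the place of the methyl alone carries a large step: 3-methylphenyl in place of 2-methylphenyl on a sulfonyl sulfur gives a 100-fold lower number from compound 2 to compound 3 (2.00 log units; beyond the scatter) with the same atoms joined differently. This position therefore separates two groups that match in every count computed for them. Nothing available here gives a reason for this step.

As far as these compounds go, whether the methyl itself is needed stays open. So does how a plain phenyl, or an ethyl or methoxy group in place of the methyl, would read here.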